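This account rests on a few compounds, and the source may have more. Where it says the series, first, only, none or still open, it means among the compounds named here.

Among the measured compounds shown here, in a functional assay on SMMC-7721 cells (Homo sapiens) for cytotoxicity, read by MTT assay, with a stated time of 72 h (a higher number here means a weaker inhibitor, a lower number a stronger inhibitor), compound 1 `COc1cccc(C=C2C(=O)N(c3ccc(Cl)cc3)N(c3ccc(Cl)cc3)C2=O)c1O` gives 64900 nM and compound 2 `O=C1C(=Cc2cccc(Cl)c2)C(=O)N(c2ccc(Cl)cc2)N1c1ccc(Cl)cc1` gives 20200 nM, the lowest number so far. Compound 3 `COc1cccc(C=C2C(=O)N(c3ccc(Cl)cc3)N(c3ccc(Cl)cc3)C2=O)c1` departs from compound 2 by methoxy in place of chloro on an aromatic carbon, meta to a large group. For the measured compounds named here, the one measured step bearing on this is a 3.2-fold lower number from compound 1 to compound 2 (0.51 log units; beyond the scatter), modest but beyond the scatter, and made on the same aryl group. Compound 3 keeps the methoxy of compound 1 but has no hydroxy. A smaller rise in this assay is therefore expected, with the expected change being a 1.5-fold higher number from compound 2 to compound 3 (0.17 log units; within the scatter). For compound 3 the estimated value is 30000 nM, with an expected range of 14000 nM to 65000 nM.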

Compound 3, half-maximal inhibitory concentration: 30200 nM
Compound 3: middle estimate off by 1.0-fold (0.00 log units), on the low side; the measured number falls inside the stated range.
By their numbers in this assay, from the lowest: compounds 2 and 3 (each within the scatter of the next); then compound 1.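

At this aromatic carbon, methoxy and chloro cannot be told apart in this assay (a 1.5-fold higher number from compound 2 to compound 3 (0.17 log units; within the scatter)). Hydrogen in place of hydroxy on the 3-methoxyphenyl group gives a change beyond the scatter, though still modest (a 2.1-fold lower number from compound 1 to compound 3 (0.33 log units; beyond the scatter)), so the high number of compound 1 goes with its hydroxy rather than its methoxy. No measurement shown explains either step. Still open, going by these compounds, is whether an amine or a carboxylic acid at this carbon would separate from chloro and methoxy. Also open, on these data alone, is whether hydroxy without the neighbouring methoxy would carry the same rise.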